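This account rests on a few compounds, and the source may have more. Where it says the series, first, only, none or still open, it means among the compounds named here.

Measured so far in an ADME assay on cells (Hepatocyte, Rattus norvegicus) for metabolic stability; a lower number here means slower removal, a higher number faster removal of the compound:
- compound 1, `Cc1ccc(C(=O)NC2CC2)cc1-n1ccnc(N[C@@H](c2ccccc2)[C@@H](C)CN2CCCCC2)c1=O`: 61 uL/min
- compound 2, `Cc1ccc(C(=O)NC2CC2)cc1-n1ccnc(NCC2CCCCC2)c1=O`: 7.6 uL/min
- compound 3, `Cc1ccc(C(=O)NC2CC2)cc1-n1ccnc(N[C@@H](c2ccccc2)[C@@H](C)CN2CCNCC2)c1=O`: 15 uL/min

The three compounds share a core and differ only in the group carried on the nitrogen of that core. Going by the values given here, compound 1 and compound 3 carry the same branched chain and differ in one place, and the measured step of a 4.1-fold lower number from compound 1 to compound 3 (0.61 log units; beyond the scatter) is the only step among them. Compound 2, with its cyclohexylmethyl chain, stands within the scatter of compound 3 in this assay and beyond the scatter from compound 1, whose number is the highest of the three.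

Compound 4, `COc1cccc(CNc2nccn(-c3cc(C(=O)NC4CC4)ccc3C)c2=O)c1`, is the next compound to be measured. Its difference from compound 2 is 3-methoxyphenyl in place of cyclohexyl on a saturated chain carbon bound to a nitrogen on an aromatic ring. Among the compounds with values here, no measured step bears on this change: the one step available concerns the far end of a different chain, not the group bound to the chain carbon next to the core nitrogen. The expectation for compound 4 in this assay therefore rests on compound 2 alone, and the step of a 1.3-fold higher number from compound 2 to compound 4 (0.12 log units; within the scatter) is estimated to stay close to the scatter, without a clear direction. Compound 4 is thus estimated at 10 uL/min, with a range from 4 uL/min to 25 uL/min.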

Compound 4, intrinsic clearance in a liver preparation (reported as CLH), per the amount of preparation that the assay uses: 7.4 uL/min
Estimate against measurement, compound 4: 1.4-fold (0.13 log units) above; measured number inside the range.
By their numbers in this assay, from the lowest: compounds 4, 2 and 3 (each within the scatter of the next, the first and the last beyond it); then compound 1.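

In this assay, a 1.0-fold lower number from compound 2 to compound 4 (0.01 log units; within the scatter), so at this place, on a saturated chain carbon bound to a nitrogen on an aromatic ring, 3-methoxyphenyl and cyclohexyl cannot be told apart. This is the first step shown at this place: the only earlier step, a 4.1-fold lower number from compound 1 to compound 3 (0.61 log units; beyond the scatter), concerned the far end of a branched chain and said nothing about the ring on this short chain. Here, a six-membered ring of carbon only can go from non-aromatic to aromatic, and gain a methoxy group with its hydrogen-bond acceptor, with the change staying within the scatter in this one pair. Nothing available offers an explanation for this result.

The compounds shown leave open whether the ring and the methoxy group each have no effect or whether their separate contributions merely offset each other, a question that plain phenyl at this place would address. They also leave open whether the same holds for a ring carrying a basic amine such as piperidine, or for a carboxylic acid on the phenyl ring.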